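Swapping propargyl for cyclopropyl on an amide nitrogen

This account rests on a few compounds, and the source may have more. Where it says the series, first, only, none or still open, it means among the compounds named here.

Measured so far:
compound 1, `C#CCNC(=O)/C(C)=C(\C)c1cc(OC)c(OC)c(OC)c1`: 160 mg/kg
compound 2, `C=CCNC(=O)/C(C)=C(\C)c1ccc(Br)cc1`: 120 mg/kg

In a toxicity assay on the whole organism (strain Icem-CET (SPF Caw)) for cytotoxicity, with Mus musculus as the target (a higher number here means that more compound is needed for the effect, a lower number that less compound is needed), compound 1 gives the higher of the two numbers, with compound 2 close by at 120 mg/kg; the two values sit within the scatter of one another, so no order between them can be claimed. Compound 3, `COc1cc(/C(C)=C(\C)C(=O)NC2CC2)cc(OC)c1OC`, has not yet been measured. It differs from compound 1 in one place: cyclopropyl in place of propargyl on an amide-type nitrogen. Within the data shown here, no pair of measured compounds differing in a single place is available, so the size of this step is unknown. For compound 3 the step of a 1.1-fold lower number from compound 1 to compound 3 (0.03 log units; within the scatter) is expected to stay within the scatter. Compound 3 is therefore estimated at 150 mg/kg, within 80 mg/kg to 300 mg/kg.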

Compound 3, dose for half-maximal effect: 320 mg/kg
Estimate against measurement, compound 3: 2.1-fold (0.33 log units) below; the measured number lies above the stated range.
By their numbers in this assay, from the lowest: compounds 2, 1 and 3 (each within the scatter of the next, the first and the last beyond it).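

Among these compounds, this is the first single-place comparison at this position. In this assay, cyclopropyl in place of propargyl on an amide-type nitrogen gives a 2.0-fold higher number from compound 1 to compound 3 (0.30 log units; within the scatter), so a three-membered carbon ring and a chain with a triple bond, each of three carbons, cannot be told apart here. No available data explain this result. Open, from the compounds shown here alone, is whether a longer chain, a cyclobutyl ring or a group carrying an amine on this nitrogen would stay equally close, and whether the same swap would read alike on the core of compound 2.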